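Notes on compound 4, a fluoro analogue of compound 2

The source may report more compounds than this note shows. Statements on the series, on what has been measured and on what is new or still open speak of the compounds shown alone.

Measured so far:
compound 1 `Cc1ccc(/C=C/C(=O)Nc2nnc(-c3ccc(C)cc3)s2)cc1`: 0.61 ug/mL in a functional assay on MCF7 cells (Homo sapiens) for antiproliferative activity, read by MTT assay, with a stated time of 48 h; on this read-out higher numbers stand for weaker inhibition and lower numbers for stronger inhibition
compound 2 `Cc1ccc(/C=C/C(=O)Nc2nnc(-c3ccc(Br)cc3)s2)cc1`: 1.32 ug/mL in this assay
compound 3 `Cc1ccc(/C=C/C(=O)Nc2nnc(-c3ccc(Cl)cc3)s2)cc1`: 1.44 ug/mL in this assay

Compound 2 stands second highest of the three numbers. Its nearest neighbour is compound 3, and a 1.1-fold higher number from compound 2 to compound 3 (0.04 log units; within the scatter) lies within the scatter, so no order between the two is claimed. The gap to compound 1 is real: a 2.2-fold higher number from compound 1 to compound 2 (0.34 log units; beyond the scatter).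

Compound 4 `O=C(/C=C/c1ccc(F)cc1)Nc1nnc(-c2ccc(Br)cc2)s1` differs from compound 2 by fluoro in place of methyl on an aromatic carbon. Among the compounds with values here, no measured step concerns this position. The two steps that exist, a 2.2-fold higher number from compound 1 to compound 2 (0.34 log units; beyond the scatter) and a 2.4-fold higher number from compound 1 to compound 3 (0.37 log units; beyond the scatter), both replace methyl by a halogen on a different aromatic carbon of the shared core, and each raised the number modestly. Whether a halogen for methyl behaves the same way here is not shown by the data, so only a small shift toward a higher number is expected, a 1.4-fold higher number from compound 2 to compound 4 (0.13 log units; within the scatter), which may not clear the scatter.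

Compound 4 is therefore estimated at 1.8 ug/mL, with a range from 0.8 ug/mL to 4 ug/mL.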

Compound 4, half-maximal inhibitory concentration: 1.49 ug/mL
Compound 4: middle estimate off by 1.2-fold (0.08 log units), on the high side, within the range that was stated.
By their numbers in this assay, from the lowest: compound 1; then compounds 2, 3 and 4 (each within the scatter of the next).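

In this assay the exchange of 4-methylphenyl for 4-fluorophenyl, with the bromo group kept, gives a 1.1-fold higher number from compound 2 to compound 4 (0.05 log units; within the scatter) and so leaves compound 4 and compound 2 inseparable. Within the data shown here, this is the first reading at this position, and it differs from the halogen-for-methyl steps on the other aromatic carbon, a 2.2-fold higher number from compound 1 to compound 2 (0.34 log units; beyond the scatter) and a 2.4-fold higher number from compound 1 to compound 3 (0.37 log units; beyond the scatter), both of which lie beyond the scatter, so those steps do not carry over to this pair. No measurement at hand bears on why the two positions read differently.

The compounds shown hold only methyl and fluoro at this position, in a single pair, so an amine, a carboxylic acid or a longer chain such as propyl there remains open. Also open, going by these compounds, is whether fluoro for methyl reads the same when the other aromatic carbon carries methyl, as in compound 1, rather than bromo.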